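Truncation of the ring-nitrogen substituent to methyl

The compounds below may be only part of what the source reports. "The series", "measured", "known", "first", "only" and "open" are said of these compounds alone.

Compound 3 `O=c1ccc(-c2ccc3cn[nH]c3c2)cn1Cc1ccccc1Cl` stands second highest of the three numbers in an assay for inhibition of MAP kinase-interacting serine/threonine-protein kinase 1 (Homo sapiens), read by luminescence and ADP-Glo, with a stated time of 2 h; on this read-out higher numbers stand for weaker inhibition and lower numbers for stronger inhibition: compound 3 gives 80 nM, compound 2 `O=c1ccc(-c2ccc3cn[nH]c3c2)cn1Cc1cccc(Cl)c1` gives 37 nM, and compound 1 `O=c1ccc(-c2ccc3cn[nH]c3c2)cn1Cc1ccccc1` gives 315 nM. Two chloro substitutions lowered the number, an 8.5-fold lower number from compound 1 to compound 2 (0.93 log units; beyond the scatter) and a 3.9-fold lower number from compound 1 to compound 3 (0.60 log units; beyond the scatter), while moving the chloro gave a 2.2-fold higher number from compound 2 to compound 3 (0.33 log units; beyond the scatter). Compound 4 `Cn1cc(-c2ccc3cn[nH]c3c2)ccc1=O` carries hydrogen in place of 2-chlorophenyl on a saturated chain carbon bound to an aromatic nitrogen. For the measured compounds named here, no measured step removes the whole ring; the steps so far only add or move a chloro on it, so the numbers for compounds 1, 2 and 3 show that the ring with its chloro lowers the number but give no direct precedent for its loss. An increase in this assay beyond the scatter is therefore expected, a 19-fold higher number from compound 3 to compound 4 (1.27 log units; beyond the scatter). Compound 4 is estimated at 1500 nM, with a range from 400 nM to 6000 nM.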

Compound 4, half-maximal inhibitory concentration: > 2000 nM
Compound 4: no number, only a limit; the forecaster's own chance of this, stated with the estimate: 10%; at least 1.3-fold (0.12 log units) between middle value and limit.
By their numbers in this assay, from the lowest: compound 2; then compound 3; then compound 1. At a limit, above all of these: compound 4.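

In this assay compound 4 gives > 2000 nM, which is a limit of the assay and not a number. Removing the ring costs far more than the chloro changes suggested for the two chloro analogues: an at least 25-fold higher number from compound 3 to compound 4 (1.39 log units; beyond the scatter) and an at least 54-fold higher number from compound 2 to compound 4 (1.73 log units; beyond the scatter). The unsubstituted phenyl also counts on its own, not only the chloro on it: an at least 6.3-fold higher number from compound 1 to compound 4 (0.80 log units; beyond the scatter).

Going by these compounds, the full size of these steps stays open, as compound 4 gives only a limit. Also open, on these data alone, is whether a longer chain such as propyl, or a saturated ring such as cyclohexyl, on that carbon would restore the lower numbers.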